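Replacing Benzyl by Propyl on the Shared Core

A few compounds are considered here, and "the series" means these few. Any claim that something is new, unique, unknown or untested is made for them only; others in the source may bear on it.

Compound 3 `CN1CCN(CCNC(=O)n2c(=O)n(Cc3ccccc3)c3ccccc32)CC1` stands at a limit in a functional assay for antagonist activity at 5-hydroxytryptamine receptor 4 (Cavia porcellus); a lower number here means a less potent compound, a higher number a more potent compound, by a factor of ten per unit of this negative logarithm: its value of < 6 is a limit of the assay and not a number. Compound 2 `CC(C)n1c(=O)n(C(=O)NCCN2CCN(C)CC2)c2ccccc21` likewise reaches only the limit < 6 in this assay. For the measured compounds named here, compound 1 `CCn1c(=O)n(C(=O)NCCN2CCN(C)CC2)c2ccccc21` is the one compound of the three with a measured number, giving 6.79 in this assay. The step of a number at least 0.79 log units lower from compound 1 to compound 3 (beyond the scatter), phenyl in place of methyl on a saturated chain carbon bound to an aromatic nitrogen, and the step of a number at least 0.79 log units lower from compound 1 to compound 2 (beyond the scatter), methyl in place of hydrogen on a saturated chain carbon, are both at least modest drops, and both end at the limit of < 6 in this assay, at which 2 of the 3 values shown sit. The step that the two limits leave unreadable from compound 2 to compound 3 cannot be read, since both of its ends sit at that limit.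

Compound 4 `CCCn1c(=O)n(C(=O)NCCN2CCN(C)CC2)c2ccccc21` differs from compound 3 by ethyl in place of phenyl on a saturated chain carbon bound to an aromatic nitrogen. This largely undoes the change from compound 1 to compound 3, leaving a chain one carbon longer than the ethyl of compound 1. Compound 1, with its 6.79, is therefore the nearest anchor. The expected step is a number at least 0.50 log units higher from compound 3 to compound 4 (beyond the scatter), upward and beyond the scatter. Compound 4 is estimated at 6.5, within a range from 5.9 to 7.1 in this assay.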

Compound 4, negative logarithm of the antagonist equilibrium constant: < 6
Compound 4: only a limit was reported; the forecaster's own chance of this, stated with the estimate: 20%; middle value at least 0.50 log units away from the limit.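

In this assay compound 4 gives < 6 as a limit of the assay and not a number, so the steps among compound 2, compound 3 and compound 4 cannot be read, and no order among isopropyl, benzyl and propyl can be given. Lengthening the straight chain by one carbon gives a number at least 0.79 log units lower from compound 1 to compound 4 (beyond the scatter) and so shows that a drop at this position does not require the branch of compound 2 or the phenyl of compound 3. Among the compounds shown, ethyl on the aromatic nitrogen is now the only group that gives a measured number, while propyl joins isopropyl and benzyl at the same limit: the limit of < 6 in this assay, at which 3 of the 4 values shown sit.

The compounds shown leave open whether a methyl group on this aromatic nitrogen would match or exceed the value of compound 1 at 6.79 in this assay. Going by these compounds, they also leave open how far compound 2, compound 3 and compound 4 lie under their shared limit, so the size of the loss for each group remains unknown.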